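A few compounds are considered here, and "the series" means these few. Any claim that something is new, unique, unknown or untested is made for them only; others in the source may bear on it.

Measured compounds:
Compound 1 `CC(C)=CCC/C(C)=C/CC1Cc2c(OCc3ccccc3)cc(=O)n(CCCO)c2CC1(C)C`; in a functional assay on PANC-1 cells (Homo sapiens) for inhibition, read by MTT assay, with a stated time of 24 h, tested at 10 uM (a higher number here means more inhibition at the concentration tested (going by the name of the read-out), a lower number less inhibition), compound 1 gives 1.5%.
Compound 2 `CC(C)=CCC/C(C)=C/CC1Cc2c(OCCCOc3ccc(Cl)cc3)cc(=O)n(CCCO)c2CC1(C)C`; in this assay compound 2 gives 0%.
Compound 3 `CC(C)=CCC/C(C)=C/CC1Cc2c(OC(=O)Nc3ccc(F)c(Cl)c3)cc(=O)n(CCCO)c2CC1(C)C`; in this assay compound 3 gives 0%.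

Compound 3 stands level with compound 2 at the digits reported, and compound 1 lies within the scatter of both, as the steps of a number 1.5 percentage points lower from compound 1 to compound 3 (within the scatter) and no change at the digits printed from compound 2 to compound 3 (within the scatter) show; the step of a number 1.5 percentage points lower from compound 1 to compound 2 (within the scatter) is likewise within the scatter. All three numbers sit close to zero in this assay.

Compound 4 `CC(C)=CCC/C(C)=C/CC1Cc2c(OC(=O)Nc3ccc(Cl)cc3)cc(=O)n(CCCO)c2CC1(C)C` differs from compound 3 by 4-chlorophenyl in place of 3-chloro-4-fluorophenyl on an amide-type nitrogen. Among the compounds with values here, none of the measured steps touches the group on the amide-type nitrogen; the steps that exist alter the group on the oxygen of the aromatic ring, and every one of them stays within the scatter. Within the data shown here, there is thus no measured step that bears directly on this change, and the compounds measured so far show nothing that moves this assay beyond the scatter. Compound 4 is therefore expected to show no step beyond the scatter, a number 1 percentage points higher from compound 3 to compound 4 (within the scatter). The estimated value for compound 4 is 1%, in the range 0% to 10%.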

Compound 4, a percentage reported as inhibition, at one concentration (the size of the read-out at that concentration, not a potency): 4.3%
Compound 4: the middle estimate sits 3.3 percentage points below what was measured, and the stated range covers the measured number.
By their numbers in this assay, from the lowest: compounds 2, 3, 1 and 4 (each within the scatter of the next).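

This is the only step shown that touches the amide-type nitrogen: in this assay, 4-chlorophenyl in place of 3-chloro-4-fluorophenyl gives a number 4.3 percentage points higher from compound 3 to compound 4 (within the scatter), so this exchange does not move the number beyond the scatter. The larger exchanges on the oxygen on an aromatic ring also stay within it, with a number 4.3 percentage points higher from compound 2 to compound 4 (within the scatter) and a number 2.8 percentage points higher from compound 1 to compound 4 (within the scatter), so (4-chlorophenyl)carbamoyl cannot be separated from the other groups at that oxygen. No measurement is available that could account for these small differences.

The compounds shown leave open whether any group on the amide-type nitrogen can move this read-out beyond the scatter. A phenyl ring carrying an amine or a carboxylic acid, or a longer alkyl chain in place of the ring, would test this.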